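This account rests on a few compounds, and the source may have more. Where it says the series, first, only, none or still open, it means among the compounds named here.

Of the compounds shown here, three built on one shared core have been tested in an ADME assay on microsomes from liver (Mus musculus) for metabolic stability, with a stated time of 30 min; a lower number here means that less of the compound is left, a higher number that more of the compound is left. Compound 1 `CCn1c(=O)/c(=C2\Sc3c(F)cccc3N2C)s/c1=C\c1ccccn1` gives 12%. Compound 2 `CCn1c(=O)/c(=C2\Sc3c(Cl)cccc3N2C)s/c1=C\c1ccccn1` differs from it by a single change, (chloro in place of fluoro on an aromatic carbon), and gives 17%; the step is a number 5 percentage points higher from compound 1 to compound 2 (within the scatter). Compound 3 `CCn1c(=O)/c(=C2\Sc3cc(F)ccc3N2C)s/c1=C\c1ccncc1` gives 13%; the difference between its core and the core of compound 1 is not broken down here, and its value and that of compound 1 lie within the scatter of each other.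

Compound 4 `CCn1c(=O)/c(=C2\Sc3cc(Cl)ccc3N2C)s/c1=C\c1ccncc1` has not yet been measured. It differs from compound 3 by chloro in place of fluoro on an aromatic carbon. Going by the values given here, this is the same kind of change as the one from compound 1 to compound 2, but the surroundings differ: there the place was ortho to a fused ring and meta to a fused ring, here it is meta to a fused ring and para to a fused ring. For compound 4 the step expected here is a number 4 percentage points higher from compound 3 to compound 4 (within the scatter) because the earlier measured step was a number 5 percentage points higher from compound 1 to compound 2 (within the scatter). Compound 4 is therefore estimated at 17%, most likely between 8% and 28%.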

Compound 4, percent of the compound remaining: 39%
Estimate against measurement, compound 4: 22 percentage points below, outside the stated range (above it).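

Chloro in place of fluoro on an aromatic carbon now gives a number 26 percentage points higher from compound 3 to compound 4 (beyond the scatter) in this assay, meaning that more of the compound is left at the end of the test. Set beside the earlier pair, this swap does not carry over from one core to another as a step of fixed size: the same change on two cores in this assay, a number 5 percentage points higher (within the scatter) from compound 1 to compound 2 and a number 26 percentage points higher (beyond the scatter) from compound 3 to compound 4, 21 percentage points apart, beyond the scatter of two such steps This shows that the same swap can give clearly different steps within this series, but it does not show which difference between the two cores matters, whether the place of the halogen (here meta to a fused ring and para to a fused ring) or another part of the structure, and two pairs give no rule for other cores.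

The compounds shown leave open how a bromo, a methyl or a nitrile at this same place would compare with chloro. They also leave open which size of step the same swap would give on a third core.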